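The compounds below may be only part of what the source reports. "The series", "measured", "known", "first", "only" and "open" are said of these compounds alone.

Of the compounds shown here, three have been measured so far, and one more awaits testing. Compound 1, with structure `O=C1COc2ccc(-c3cccc(NS(=O)(=O)c4ccc(F)cc4)c3)cc2N1C1CC1`, carries a cyclopropyl group on the ring nitrogen of the shared core. In a functional assay on HCT-116 cells (Homo sapiens) for antiproliferative activity, read by MTT assay, with a stated time of 72 h (on this read-out higher numbers stand for weaker inhibition and lower numbers for stronger inhibition), compound 1 gives > 40000 nM, which is a limit of the assay and not a number. Compound 3, with structure `O=C1COc2ccc(-c3cnc4ccccc4c3)cc2N1c1ccccc1`, also reaches only a limit; in this assay compound 3 gives > 40000 nM. For the measured compounds named here, compound 2, with structure `O=C1COc2ccc(-c3cnc(Cl)c(NS(=O)(=O)c4ccc(F)cc4)c3)cc2N1c1ccccc1`, is the one compound with a number: in this assay compound 2 gives 39800 nM. Going by the values given here, compound 2 therefore stands as the only measured value, while the other two sit at the limit of > 40000 nM in this assay, at which 2 of the 3 values shown sit, and even its own number lies close to that limit.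

Compound 4, with structure `CC(C)N1C(=O)COc2ccc(-c3cnc(Cl)c(NS(=O)(=O)c4ccc(F)cc4)c3)cc21`, is reached from compound 2 by a single change: isopropyl in place of phenyl on an amide-type nitrogen in a ring. Among the compounds with values here, no measured pair differs in this one place, so there is no step to lean on, and compound 1, the only compound bearing a small non-aromatic group on that nitrogen, differs elsewhere as well.

With nothing to guide the direction, the step expected a 1.0-fold higher number from compound 2 to compound 4 (0.00 log units; within the scatter) is none beyond the scatter. Compound 4 is thus estimated at 40000 nM, within 15000 nM to 100000 nM.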

Compound 4, half-maximal inhibitory concentration: 18900 nM
Beside the measured number, compound 4's estimate is 2.1-fold (0.33 log units) above it, within the range that was stated.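

For the compounds shown here, the change from phenyl to isopropyl on the amide-type nitrogen in a ring gives the first step that can be read at this position, as no earlier pair differed in this one place: in this assay it is a 2.1-fold lower number from compound 2 to compound 4 (0.32 log units; beyond the scatter). The step is modest, but it shows that this position can change the read-out and that, for this pair, an aromatic ring on the nitrogen is not required for the number to fall, since the isopropyl group that enters has no ring and fewer heavy atoms. Both ends of this step are real numbers and not limits, which matters in a set this small, where much of the data gives nothing to compare: the limit of > 40000 nM in this assay, at which 2 of the 4 values shown sit.

Phenyl and isopropyl differ both in size and in the presence of a ring, so this one step cannot tell which of the two goes with the lower number. As far as these compounds go, compound 1 also differs elsewhere, so its cyclopropyl group does not settle this, and how a methyl group, a longer chain ending in an amine or one ending in a carboxylic acid would read on this nitrogen remains open.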